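Compound 3: acetamido in place of cyano

The source may report more compounds than this note shows. Statements on the series, on what has been measured and on what is new or still open speak of the compounds shown alone.

Of the compounds shown here, two on a shared core have been measured so far. In a functional assay on QGY-7703 cells (Homo sapiens) for cytotoxicity, read by MTT assay, with a stated time of 24 h (a higher number here means a weaker inhibitor, a lower number a stronger inhibitor), compound 1 `O=C1/C(=C/c2cccnc2)CN(S(=O)(=O)c2ccc(Br)cc2)C/C1=C\c1ccccc1C(F)(F)F` gives 5510 nM and compound 2 `N#Cc1ccc(S(=O)(=O)N2C/C(=C\c3cccnc3)C(=O)/C(=C/c3ccccc3C(F)(F)F)C2)cc1` gives 6150 nM. Going by the values given here, compound 2 therefore sits within the scatter of compound 1, the only other measured compound. Compound 3 `CC(=O)Nc1ccc(S(=O)(=O)N2C/C(=C\c3cccnc3)C(=O)/C(=C/c3ccccc3C(F)(F)F)C2)cc1` carries acetamido in place of cyano on an aromatic carbon, para to a large group: acetamido in place of cyano on an aromatic carbon. Among the compounds with values here, one measured step bears on this place: a 1.1-fold higher number from compound 1 to compound 2 (0.05 log units; within the scatter), with cyano in place of bromo. Within the data shown here, no measured compound carries acetamido, so this evidence is thin. No step beyond the scatter is expected in this assay, and no direction is favoured. The expected change is a 1.0-fold lower number from compound 2 to compound 3 (0.01 log units; within the scatter). For compound 3 the estimate is 6000 nM, with an expected range of 2500 nM to 14000 nM.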

Compound 3, half-maximal inhibitory concentration: 5380 nM
Beside the measured number, compound 3's estimate is 1.1-fold (0.05 log units) above it; low and high end bracket the measured number.
By their numbers in this assay, from the lowest: compounds 3, 1 and 2 (each within the scatter of the next).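

In this assay, the change from 4-cyanophenyl to 4-acetamidophenyl gives a 1.1-fold lower number from compound 2 to compound 3 (0.06 log units; within the scatter) and acetamido in place of bromo gives a 1.0-fold lower number from compound 1 to compound 3 (0.01 log units; within the scatter) on the same aromatic carbon. The earlier pair covered only bromo and cyano; the position, para to a large group, now also holds acetamido, which adds a hydrogen-bond donor and a larger substituent without a step beyond the scatter in either comparison. No measurement on hand accounts for these small steps.

From the compounds shown here alone, whether an amine, a carboxylic acid or a longer acyl chain at this position would stay within the scatter remains open. The other parts of the shared core do not vary among the compounds shown, which leaves their bearing on the number unresolved.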